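From 3-ethylphenyl to 2,5-dimethylphenyl on the sulfonamide nitrogen

The source may hold more compounds than are shown below. What is called first, only, known or untested is meant among the compounds shown, and "the series" means these compounds.

In a functional assay on CHO cells (Homo sapiens) for antiproliferative activity against CHO (Cricetulus griseus), read by sulforhodamine B assay, with a stated time of 48 h (on this read-out lower numbers stand for stronger inhibition and higher numbers for weaker inhibition), compound 1 `CCc1cccc(NS(=O)(=O)c2ccc(N3CCNC3=O)cc2)c1` gives 230 nM and compound 2 `O=C1NCCN1c1ccc(S(=O)(=O)Nc2cccc(Br)c2)cc1` gives 250 nM, so the two values lie within the scatter of each other. Compound 3 `Cc1ccc(C)c(NS(=O)(=O)c2ccc(N3CCNC3=O)cc2)c1` is still unmeasured and carries 2,5-dimethylphenyl in place of 3-ethylphenyl on a sulfonamide nitrogen, (2,5-dimethylphenyl in place of 3-ethylphenyl on a sulfonamide nitrogen). Among the compounds with values here, the only measured step, a 1.1-fold higher number from compound 1 to compound 2 (0.04 log units; within the scatter), comes from a different change, bromo in place of ethyl on an aromatic carbon, so it offers weak guidance and no shift beyond the scatter is expected. The expected step is a 1.3-fold higher number from compound 1 to compound 3 (0.12 log units; within the scatter). For compound 3 the estimated value is 300 nM, with an expected range of 100 nM to 900 nM.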

Compound 3, half-maximal inhibitory concentration: 77 nM
For compound 3 the middle estimate is 3.9-fold (0.59 log units) above the measured one; measured number below the stated range.
By their numbers in this assay, from the lowest: compound 3; then compounds 1 and 2 (each within the scatter of the next).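

In this assay, 2,5-dimethylphenyl in place of 3-ethylphenyl on the sulfonamide nitrogen gives a 3.0-fold lower number from compound 1 to compound 3 (0.48 log units; beyond the scatter) and in place of 3-bromophenyl gives a 3.2-fold lower number from compound 2 to compound 3 (0.51 log units; beyond the scatter). Both 2,5-dimethylphenyl and 3-ethylphenyl have the same count of carbon atoms, so this position distinguishes between two arrangements of the same atoms, which the earlier bromo-for-ethyl step did not show. Nothing available explains this difference. As far as these compounds go, it remains open whether a single methyl, as in 2-methylphenyl or 3-methylphenyl, would give the same result. From the compounds shown here alone, how an amine or a carboxylic acid on this ring would read out is also open.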